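A Side-Chain Swap on a Shared Core

The compounds below may be only part of what the source reports. "The series", "measured", "known", "first", "only" and "open" are said of these compounds alone.

Of the compounds shown here, two on a shared core have been measured. Compound 1 `O=C(CN(c1ncnc2c1ncn2C1CCCCO1)C1CC1)N[C@@H](CO)C(=O)OCc1ccccc1` gives 32.2% in a functional assay on the whole organism (Tail, strain ICR) with Mus musculus as the target, in the tail flick test, with a stated time of 90 min, at a dose of 25 umol/kg by the oral route; on this read-out higher numbers stand for a stronger effect at the one dose given and lower numbers for a weaker effect. Compound 2 `NC(=O)C[C@H](NC(=O)CN(c1ncnc2c1ncn2C1CCCCO1)C1CC1)C(=O)OCc1ccccc1` gives 35% in this assay. Compound 2 stands highest of the two numbers, yet the step of a number 2.8 percentage points higher from compound 1 to compound 2 (within the scatter) is within the scatter, so the two cannot be told apart.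

Compound 3 `N=C(N)NCCC[C@H](NC(=O)CN(c1ncnc2c1ncn2C1CCCCO1)C1CC1)C(=O)OCc1ccccc1` differs from compound 2 in one place: a group of 6 heavy atoms (3 carbon, 3 nitrogen; no ring) in place of a group of 3 heavy atoms (1 carbon, 1 nitrogen, 1 oxygen; no ring), on a saturated chain carbon, two bonds along the chain from an amide-type nitrogen and a carbonyl carbon. Among the compounds with values here, the only measured step, from compound 1 to compound 2, also changed this position and was within the scatter, but the group it brought in differs from the group entering in compound 3, as the counted difference shows. Within the data shown here, no measured step of this kind exists, so the expected step of a number 2 percentage points lower from compound 2 to compound 3 (within the scatter) is set near zero with a wide margin. For compound 3 the estimate in this assay is 33%, expected to fall between 15% and 52%.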

Compound 3, a percentage reported as activity, at one dose (the size of the read-out at that dose, not a potency): 61.6%
For compound 3 the middle estimate is 28.6 percentage points below the measured one; the measured number lies above the stated range.
By their numbers in this assay, from the lowest: compounds 1 and 2 (each within the scatter of the next); then compound 3.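

This place on the saturated chain carbon is not indifferent in this assay: carbamoyl in place of hydroxy left the read-out within the scatter, but the group of 6 heavy atoms (3 carbon, 3 nitrogen; no ring) gives a number 26.6 percentage points higher from compound 2 to compound 3 (beyond the scatter) and a number 29.4 percentage points higher from compound 1 to compound 3 (beyond the scatter). Among the three compounds, then, only compound 3 stands apart from the others, and it stands on the high side at the one dose and time given. Nothing shown here explains why this group differs from the other two.

From the compounds shown here alone, it remains open whether the whole chain or only its nitrogen-bearing end matters, which a simple amine or a carboxylic acid on a chain at this place could help to separate. A shorter or longer chain ending in the same group would show how much the chain length counts.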